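Methyl for fluoro on the ketone-side aryl of the boron series

This account rests on a few compounds, and the source may have more. Where it says the series, first, only, none or still open, it means among the compounds named here.

Measured compounds in a toxicity assay on WI-38 cells (Homo sapiens) for cytotoxicity, read by MTT assay, with a stated time of 48 h; on this read-out higher numbers stand for weaker inhibition and lower numbers for stronger inhibition:
- compound 1 `O=C(/C=C/c1ccc2c(c1)B(O)OC2)c1ccc(F)cc1`: 7600 nM
- compound 2 `CCc1ccc(C(=O)/C=C/c2ccc3c(c2)B(O)OC3)cc1`: 20600 nM
- compound 3 `CCOC(=O)c1ccc(C(=O)/C=C/c2ccc3c(c2)B(O)OC3)cc1`: 47200 nM

Compound 1 gives the lowest number of the three; its nearest neighbour is compound 2 with a 2.7-fold higher number from compound 1 to compound 2 (0.43 log units; beyond the scatter), and the furthest is compound 3 with a 6.2-fold higher number from compound 1 to compound 3 (0.79 log units; beyond the scatter). Between the two larger groups, the step runs a 2.3-fold higher number from compound 2 to compound 3 (0.36 log units; beyond the scatter).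

The unmeasured compound 4 `Cc1cccc(C(=O)/C=C/c2ccc3c(c2)B(O)OC3)c1` departs from compound 1 by 3-methylphenyl in place of 4-fluorophenyl on a carbonyl carbon. Within the data shown here, no measured step exchanges one aryl for another wholly; the closest analogy is the step from compound 1 to compound 2, where an alkyl group replaced the fluoro on the aromatic carbon and the number rose by a 2.7-fold higher number from compound 1 to compound 2 (0.43 log units; beyond the scatter). Among the measured compounds shown here, the change to compound 4 also swaps fluoro for an alkyl, though the methyl sits at a different position on the ring, and the measured data give no step for that placement. A modest rise, as for compound 2, is therefore expected, but with more uncertainty than a directly matched step would allow.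

Compound 4 is estimated at 13000 nM, with a range of 5500 nM to 32000 nM, which means an expected step of a 1.7-fold higher number from compound 1 to compound 4 (0.23 log units; within the scatter).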

Compound 4, half-maximal inhibitory concentration: 16700 nM
Estimate against measurement, compound 4: 1.3-fold (0.11 log units) below, within the range that was stated.
By their numbers in this assay, from the lowest: compound 1; then compounds 4 and 2 (each within the scatter of the next); then compound 3.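

In this assay, 3-methylphenyl in place of 4-fluorophenyl on a carbonyl carbon gives a 2.2-fold higher number from compound 1 to compound 4 (0.34 log units; beyond the scatter), so exchanging the whole aryl group also leaves a number beyond the scatter from that of compound 1. Across the compounds shown, each of the three without fluoro, compound 2, compound 3 and compound 4, gives a higher number than compound 1, and none goes against this. Compound 2 at 20600 nM and compound 4 at 16700 nM lie within the scatter of each other, so on these numbers the ethyl-bearing and the 3-methylphenyl compounds cannot be ranked; no measurement offered here gives a reason for any of these differences.

The step to compound 4 removes the fluoro and changes the placement of the ring substituent together, and the two contributions cannot be separated from these compounds alone. An unsubstituted phenyl group on the carbonyl carbon would help to separate them, while a chloro group, an amine or a carboxylic acid on that aryl ring remains an open question for this read-out.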